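Chain length between amide and piperidine, two cores compared

A few compounds are considered here, and "the series" means these few. Any claim that something is new, unique, unknown or untested is made for them only; others in the source may bear on it.

Values in a functional assay on a cell-free system (Platelet, plasma, Homo sapiens) for inhibition; on this read-out lower numbers stand for stronger inhibition and higher numbers for weaker inhibition:
compound 1 `O=C(O)CN1Cc2ccc(NC(=O)CCCC3CCNCC3)cc2C1=O`: 66000 nM
compound 2 `O=C(O)CN1Cc2ccc(NC(=O)CC3CCNCC3)cc2C1=O`: 51000 nM
compound 3 `O=C(O)CCN1Cc2ccc(NC(=O)CC3CCNCC3)cc2C1=O`: 7400 nM

Compound 3 gives the lowest of the three numbers; both its steps to the others lie beyond the scatter. The core of compound 3 differs from the core of compound 2 by carboxymethyl in place of carboxy on a saturated chain carbon bound to an amide-type nitrogen in a ring, a change that reads a 6.9-fold lower number from compound 2 to compound 3 (0.84 log units; beyond the scatter). On the core of compound 2, the change 2-(piperidin-4-yl)ethyl in place of piperidin-4-yl on a saturated chain carbon bound to a carbonyl carbon leads to compound 1 and reads a 1.3-fold higher number from compound 2 to compound 1 (0.11 log units; within the scatter), within the scatter.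

Compound 4 `O=C(O)CCN1Cc2ccc(NC(=O)CCCC3CCNCC3)cc2C1=O` carries the same change on the core of compound 3: 2-(piperidin-4-yl)ethyl in place of piperidin-4-yl on a saturated chain carbon bound to a carbonyl carbon, at the same place. The earlier step of a 1.3-fold higher number from compound 2 to compound 1 (0.11 log units; within the scatter) stayed within the scatter. On that basis compound 4 is expected to move by a 1.2-fold higher number from compound 3 to compound 4 (0.09 log units; within the scatter). Compound 4 is estimated at 9000 nM, with a range from 3500 nM to 25000 nM.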

Compound 4, half-maximal inhibitory concentration: 5900 nM
Compound 4: middle estimate off by 1.5-fold (0.18 log units), on the high side; the range from low to high includes it.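

Putting 2-(piperidin-4-yl)ethyl in place of piperidin-4-yl on the core of compound 3 gives a 1.3-fold lower number from compound 3 to compound 4 (0.10 log units; within the scatter), and this flat result matches the one on the other core: the same change on two cores in this assay, a 1.3-fold higher number (0.11 log units; within the scatter) from compound 2 to compound 1 and a 1.3-fold lower number (0.10 log units; within the scatter) from compound 3 to compound 4, 1.6-fold (0.21 log units) apart, within the scatter of two such steps

The carboxymethyl for carboxy change, seen here as an 11-fold lower number from compound 1 to compound 4 (1.05 log units; beyond the scatter), also carries over between the two cores: the same change on two cores in this assay, a 6.9-fold lower number (0.84 log units; beyond the scatter) from compound 2 to compound 3 and an 11-fold lower number (1.05 log units; beyond the scatter) from compound 1 to compound 4, 1.6-fold (0.21 log units) apart, within the scatter of two such steps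

These two changes therefore read as independent of each other in this small set, but that rests on a single pair of cores and says nothing about other cores or other groups at these places.

Going by these compounds, it remains open whether a longer chain in place of carboxymethyl would bring the number lower still. Also open, on these data alone, is whether an open-chain amine could stand in place of the piperidin-4-yl group.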